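This account rests on a few compounds, and the source may have more. Where it says the series, first, only, none or still open, it means among the compounds named here.

Of the compounds shown here, two built on a shared core have been measured in an assay for binding affinity to Amine oxidase [flavin-containing] A (Homo sapiens); on this read-out lower numbers stand for stronger inhibition and higher numbers for weaker inhibition. Compound 1 `O=Cc1cn(C[C@H]2CN(c3ccc(C4=CCS(=O)(=O)CC4)c(F)c3)C(=O)O2)nn1` gives 3200 nM in this assay. Compound 2 `CC(C)(C)OC(=O)c1cn(C[C@H]2CN(c3ccc(C4=CCS(=O)(=O)CC4)c(F)c3)C(=O)O2)nn1` gives 3500 nM in this assay, and the step of a 1.1-fold higher number from compound 1 to compound 2 (0.04 log units; within the scatter) lies within the scatter, so the two numbers cannot be told apart. Compound 3 `Cc1cn(C[C@H]2CN(c3ccc(C4=CCS(=O)(=O)CC4)c(F)c3)C(=O)O2)nn1` differs from compound 2 by methyl in place of tert-butoxycarbonyl on an aromatic carbon. Among the measured compounds shown here, the only measured step that bears on this position is a 1.1-fold higher number from compound 1 to compound 2 (0.04 log units; within the scatter), which shows that two quite different groups on this aromatic carbon give numbers within the scatter of each other. On that basis compound 3 is expected to give a number close to that of compound 2, with the estimated step of a 1.2-fold lower number from compound 2 to compound 3 (0.07 log units; within the scatter) not beyond the scatter. Compound 3 is therefore estimated at 3000 nM in this assay, with a range from 1200 nM to 8000 nM.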

Compound 3, inhibition constant: 25000 nM
For compound 3 the middle estimate is 8.3-fold (0.92 log units) below the measured one; measured number above the stated range.
By their numbers in this assay, from the lowest: compounds 1 and 2 (each within the scatter of the next); then compound 3.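

In this assay this aromatic carbon of the five-membered ring with 3 nitrogen proves sensitive to its substituent after all: methyl in place of tert-butoxycarbonyl gives a 7.1-fold higher number from compound 2 to compound 3 (0.85 log units; beyond the scatter) and methyl in place of formyl gives a 7.8-fold higher number from compound 1 to compound 3 (0.89 log units; beyond the scatter) in the same direction. The earlier agreement between the formyl and tert-butoxycarbonyl groups therefore does not extend to every group at this position, and among these three compounds only the methyl, the one group without a carbonyl, stands apart. Nothing available explains this difference.

The compounds shown leave open whether the carbonyl itself separates the two groups from methyl, or whether another feature of the groups does. A hydroxymethyl, an amide or a carboxylic acid on this carbon could help to tell these readings apart, as could a longer alkyl chain.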